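Taking the butyl group off compound 3

A few compounds are considered here, and "the series" means these few. Any claim that something is new, unique, unknown or untested is made for them only; others in the source may bear on it.

Measured so far in a functional assay on J774.A1 cells (Mus musculus) for inhibition, read by Griess assay, with stated times of 1 h and 24 h (a lower number here means a stronger inhibitor, a higher number a weaker inhibitor), are three compounds:
compound 1 `CC(C)COc1ccccc1C1CC(=O)c2ccccc2O1` gives 33200 nM in this read-out
compound 2 `CC(C)=CCOc1ccccc1C1CC(=O)c2ccccc2O1` gives 34300 nM in this read-out
compound 3 `CCCCOc1ccccc1C1CC(=O)c2ccccc2O1` gives 47700 nM in this read-out

The numbers place compound 3 together with the other two, with a 1.4-fold higher number from compound 1 to compound 3 (0.16 log units; within the scatter) and a 1.4-fold higher number from compound 2 to compound 3 (0.14 log units; within the scatter) as its two steps. Next comes compound 4 `O=C1CC(c2ccccc2O)Oc2ccccc21`, which differs from compound 3 as follows: hydrogen in place of butyl on an oxygen on an aromatic ring. In words, hydrogen stands in place of butyl on an oxygen on an aromatic ring, butoxy to hydroxy.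

Going by the values given here, three measured steps bear on this position: the two above and a 1.0-fold higher number from compound 1 to compound 2 (0.01 log units; within the scatter) in this assay. Each exchanges one chain for another on that oxygen, and all stay within the scatter. None removes the chain altogether, so the series gives only indirect guidance for a free hydroxy, and the uncertainty is wide. With no measured evidence for a direction, no step beyond the scatter is expected, and the estimate starts from compound 3 at 47700 nM in this assay. The estimate corresponds to an expected 1.0-fold higher number from compound 3 to compound 4 (0.02 log units; within the scatter) in this assay. For compound 4 the expected value is 50000 nM, with 18000 nM to 130000 nM as the estimated range.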

Compound 4, half-maximal inhibitory concentration: 71300 nM
Estimate against measurement, compound 4: 1.4-fold (0.15 log units) below, and the stated range covers the measured number.
By their numbers in this assay, from the lowest: compounds 1, 2, 3 and 4 (each within the scatter of the next, the first and the last beyond it).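

Going by these compounds alone, compound 4 is the first entry in this assay that carries no chain at all on the oxygen on the aromatic ring, so the series now holds a direct comparison of butoxy to hydroxy rather than only exchanges of one chain for another. Within the data shown here, the result depends on which chain is taken as the reference: the step from butyl stays within the scatter (a 1.5-fold higher number from compound 3 to compound 4 (0.17 log units; within the scatter)), while the steps from 3-methylbut-2-en-1-yl (a 2.1-fold higher number from compound 2 to compound 4 (0.32 log units; beyond the scatter)) and from isobutyl (a 2.1-fold higher number from compound 1 to compound 4 (0.33 log units; beyond the scatter)) lie modestly beyond it, and these two are the first differences to do so; compound 3 is therefore the exception to any reading that all of the chains differ from the free hydroxy. No accompanying measurement offers an explanation for these steps.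

Open, as far as these compounds go, is how a methyl or ethyl group on this oxygen would compare with the free hydroxy and with the butyl, isobutyl and 3-methylbut-2-en-1-yl chains. Also open, from the compounds shown here alone, is whether a longer chain such as hexyl, or a chain ending in an amine or a carboxylic acid, would move the number beyond the narrow spread seen so far.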